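The source may hold more compounds than are shown below. What is called first, only, known or untested is meant among the compounds shown, and "the series" means these compounds.

compound 1 (`COc1cc(OC)c(-c2coc3cc(OCc4ccc(F)cc4)ccc3c2=O)cc1OC`) 950 nM
compound 2 (`COc1cc(OC)c(-c2coc3cc(OCc4ccccc4C)ccc3c2=O)cc1OC`) 2900 nM
compound 3 (`COc1cc(OC)c(-c2coc3cc(OCc4cccc(Cl)c4)ccc3c2=O)cc1OC`) 1330 nM

In a functional assay on HCT-116 cells (Homo sapiens) for antiproliferative activity, read by MTT assay, with a stated time of 24 h (on this read-out lower numbers stand for stronger inhibition and higher numbers for weaker inhibition), compound 3 cannot be separated from compound 1 and gives a lower number than compound 2. The next change leads to compound 4 (`COc1cc(OC)c(-c2coc3cc(OCc4ccc(C(F)(F)F)cc4)ccc3c2=O)cc1OC`), with 4-(trifluoromethyl)phenyl in place of 3-chlorophenyl on a saturated chain carbon bound to an oxygen on an aromatic ring.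

Three measured steps change this same aryl group. Two are modest, a 3.1-fold higher number from compound 1 to compound 2 (0.48 log units; beyond the scatter) and a 2.2-fold lower number from compound 2 to compound 3 (0.34 log units; beyond the scatter), and both involve 2-methylphenyl, which compound 4 lacks. The third, a 1.4-fold higher number from compound 1 to compound 3 (0.15 log units; within the scatter), stays within the scatter. No step beyond the scatter is therefore expected in this assay. The expected change is a 1.0-fold lower number from compound 3 to compound 4 (0.01 log units; within the scatter). For compound 4 the estimated value is 1300 nM, with an expected range of 550 nM to 3100 nM.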

Compound 4, half-maximal inhibitory concentration: 2440 nM
The estimate for compound 4 lay 1.9-fold (0.27 log units) below the measured number, within the range that was stated.
By their numbers in this assay, from the lowest: compounds 1, 3, 4 and 2 (each within the scatter of the next, the first and the last beyond it).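

In this assay, within the data shown here, trifluoromethyl in place of fluoro on an aromatic carbon gives the first step beyond the scatter at this position that does not involve 2-methylphenyl (a 2.6-fold higher number from compound 1 to compound 4 (0.41 log units; beyond the scatter)). The same compound stays within the scatter of both other aryl groups (a 1.8-fold higher number from compound 3 to compound 4 (0.26 log units; within the scatter); a 1.2-fold lower number from compound 2 to compound 4 (0.08 log units; within the scatter)), so the aryl changes shown here form no clean order. No measurement is at hand to account for this step.

Still open, from the compounds shown here alone, is how an amine or a carboxylic acid on this aryl ring would read. Going by these compounds, a longer chain in place of the benzyl group is equally open.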